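Amine substitution on the shared core: methylamino to dimethylamino

The source may hold more compounds than are shown below. What is called first, only, known or untested is meant among the compounds shown, and "the series" means these compounds.

Compound 1 `CC(=N)NCC1CCCc2cc(S(=O)(=O)c3ccccc3)ccc21` is measured in an assay on isolated protein for displacement of a labelled ligand from 5-hydroxytryptamine receptor 6 (Homo sapiens) (a higher number here means a weaker inhibitor, a lower number a stronger inhibitor), where compound 1 gives 0.631 nM. Compound 2 `CNCC1CCCc2cc(S(=O)(=O)c3ccccc3)ccc21` carries one carbon atom on the amine nitrogen in place of the acetimidoyl group, and in this assay compound 2 gives 0.316 nM. The step of a 2.0-fold lower number from compound 1 to compound 2 (0.30 log units; within the scatter) lies within the scatter. Of the two numbers, compound 2 carries the lower one, yet compound 1 cannot be separated from it on this evidence.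

Compound 3 `CN(C)CC1CCCc2cc(S(=O)(=O)c3ccccc3)ccc21` differs from compound 2 by methyl in place of hydrogen on an amine nitrogen, on an amine nitrogen whose other neighbours are two saturated chain carbons; read one bond further out, methylamino becomes dimethylamino. For the measured compounds named here, the only measured step at this nitrogen, a 2.0-fold lower number from compound 1 to compound 2 (0.30 log units; within the scatter), stayed within the scatter, so no movement beyond the scatter is anticipated in this assay. Compound 3 is expected to give about 0.45 nM, in a range from 0.15 nM to 1.5 nM. The expected step of a 1.4-fold higher number from compound 2 to compound 3 (0.15 log units; within the scatter) is thus estimated to remain within the scatter.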

Compound 3, inhibition constant: 0.0631 nM
The estimate for compound 3 lay 7.1-fold (0.85 log units) above the measured number; the whole stated range lies above it.
By their numbers in this assay, from the lowest: compound 3; then compounds 2 and 1 (each within the scatter of the next).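

For the compounds shown here, at the amine nitrogen, methyl in place of hydrogen is the first change in this assay to move the number beyond the scatter, with a 5.0-fold lower number from compound 2 to compound 3 (0.70 log units; beyond the scatter). Compound 3 also separates from the acetimidoyl compound, with a 10-fold lower number from compound 1 to compound 3 (1.00 log units; beyond the scatter), whereas compound 1 and compound 2 could not be told apart, so substitution at this nitrogen does register in this assay. Nothing available bears on the reason for this shift.

Whether the trend continues is open: the primary amine, an ethyl group on this nitrogen and a pyrrolidine ring built on it would each test how far the dimethylamino result extends. Also open, going by these compounds, is whether methyl in place of hydrogen gives a step of similar size on a core other than the shared one.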